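Aryl amine variation on the shared core: propyl for acetyl

This account rests on a few compounds, and the source may have more. Where it says the series, first, only, none or still open, it means among the compounds named here.

Measured so far in an assay on FRT-Jurkat cells for inhibition of nuclear factor NF-kappa-B complex (Homo sapiens), read by flow cytometry, with a stated time of 24 h, tested at 10 uM; a higher number here means more inhibition at the concentration tested (going by the name of the read-out), a lower number less inhibition:
compound 1, `O=C1CCC(N2C(=O)c3cccc(Nc4ccccn4)c3C2=O)C(=O)N1`, gives 1%.
compound 2, `CC(C)(C)c1ccc(Nc2cccc3c2C(=O)N(C2CCC(=O)NC2=O)C3=O)cc1`, gives 36%.
compound 3, `CC(=O)c1ccc(Nc2cccc3c2C(=O)N(C2CCC(=O)NC2=O)C3=O)cc1`, gives 2%.

Compound 3 stands second highest of the three numbers, though its gap to compound 1 lies within the scatter; only compound 2 is clearly apart, a number 34 percentage points lower from compound 2 to compound 3 (beyond the scatter). Among the two other steps, a number 35 percentage points higher from compound 1 to compound 2 (beyond the scatter) is the single large movement in the set, while a number 1 percentage points higher from compound 1 to compound 3 (within the scatter) stays within the scatter.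

Compound 4, `CCCc1ccc(Nc2cccc3c2C(=O)N(C2CCC(=O)NC2=O)C3=O)cc1`, is not yet measured. The change from compound 3 is propyl in place of acetyl on an aromatic carbon. The step that bears on it most directly is a number 34 percentage points lower from compound 2 to compound 3 (beyond the scatter), where the carbon-only tert-butyl gave the high number and the acetyl, with its one acceptor, the low one. Propyl, like tert-butyl, brings no acceptor and no ring, so a rise from compound 3 is expected, though whether a three-carbon chain reproduces the full effect of tert-butyl cannot be read from these three compounds.

The estimate for compound 4 in this assay is 20%, range 2% to 40%, which means an expected step of a number 18 percentage points higher from compound 3 to compound 4 (beyond the scatter).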

Compound 4, a percentage reported as inhibition, at one concentration (the size of the read-out at that concentration, not a potency): 23%
Estimate against measurement, compound 4: 3 percentage points below; low and high end bracket the measured number.
By their numbers in this assay, from the lowest: compounds 1 and 3 (each within the scatter of the next); then compound 4; then compound 2.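

In this assay, acetyl and propyl match in heavy-atom count and neither has a ring, yet the swap gives a number 21 percentage points higher from compound 3 to compound 4 (beyond the scatter) at this aromatic carbon, so heavy-atom count alone does not set the number in this pair; the rise comes with the loss of the carbonyl and its acceptor. A carbon-only group does not by itself reach the level of compound 2: the step is a number 13 percentage points lower from compound 2 to compound 4 (beyond the scatter) when propyl stands in place of tert-butyl, so the two carbon-only groups are separated beyond the scatter. The 4-propylphenyl group also clears the pyridin-2-yl of compound 1, with a number 22 percentage points higher from compound 1 to compound 4 (beyond the scatter) on the same nitrogen, making it a second aryl group on that nitrogen to do so, while 4-acetylphenyl does not.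

On these data alone, whether a longer chain such as butyl, or a branched chain such as isopropyl, would close the remaining gap to tert-butyl stays open, as does whether a methoxy group or an amine at this carbon would track the acetyl or the propyl. The compounds shown come with no measurement that explains any of these differences.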